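A few compounds are considered here, and "the series" means these few. Any claim that something is new, unique, unknown or untested is made for them only; others in the source may bear on it.

Working notes on the amide series. Going by the values given here, compound 3 `N#CC1(NC(=O)[C@@H]2C[C@@H](S(=O)(=O)c3ccccc3)C[C@H]2C(=O)N2CCNCC2)CC1` carries the piperazin-1-yl amide and in a functional assay on A20 cells (Mus musculus) for inhibition, with stated times of 1 h, 16 h and 24 h (a lower number here means a stronger inhibitor, a higher number a weaker inhibitor), compound 3 gives 1340 nM, the highest of the three numbers measured so far. Compound 1 `N#CC1(NC(=O)[C@@H]2C[C@@H](S(=O)(=O)c3ccccc3)C[C@H]2C(=O)N2CCOCC2)CC1`, with morpholin-4-yl at the same carbonyl, gives 12 nM, and compound 2 `C[C@@H]1CN(C(=O)[C@@H]2C[C@H](S(=O)(=O)c3ccccc3)C[C@H]2C(=O)NC2(C#N)CC2)C[C@H](C)O1`, with 2,6-dimethylmorpholin-4-yl, gives 1 nM. The steps of a 110-fold higher number from compound 1 to compound 3 (2.05 log units; beyond the scatter) and a 1300-fold higher number from compound 2 to compound 3 (3.13 log units; beyond the scatter) show how far compound 3 falls behind its two neighbours, while a 12-fold lower number from compound 1 to compound 2 (1.08 log units; beyond the scatter) shows the gain on the other side.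

Compound 4 `CN(C)C(=O)[C@@H]1C[C@H](S(=O)(=O)c2ccccc2)C[C@H]1C(=O)NC1(C#N)CC1` is not yet measured. The change from compound 3 is dimethylamino in place of piperazin-1-yl on a carbonyl carbon. Of the measured steps, those from compound 1 and compound 2 to compound 3 bear most directly, since each replaces the group at this carbonyl; both are large, and the replacement of piperazin-1-yl by a group with no hydrogen-bond donor, as counted, is expected to move in the opposite direction. A large downward step, a 45-fold lower number from compound 3 to compound 4 (1.65 log units; beyond the scatter), is therefore expected, though without reaching compound 2. In this assay compound 4 is estimated at 30 nM, with a range of 6 nM to 200 nM.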

Compound 4, half-maximal inhibitory concentration: 91 nM
Beside the measured number, compound 4's estimate is 3.0-fold (0.48 log units) below it, and the stated range covers the measured number.
By their numbers in this assay, from the lowest: compound 2; then compound 1; then compound 4; then compound 3.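

Dimethylamino carries no ring, yet at this carbonyl carbon it gives a 15-fold lower number from compound 3 to compound 4 (1.17 log units; beyond the scatter), so a six-membered ring is not required for a number well under that of the piperazin-1-yl amide. Compound 4 still falls behind both morpholine amides, with a 7.6-fold higher number from compound 1 to compound 4 (0.88 log units; beyond the scatter) and the wider a 91-fold higher number from compound 2 to compound 4 (1.96 log units; beyond the scatter), which places the open-chain amide inside the span of the ring amides: two of them lie on its lower side and piperazin-1-yl on its higher side. Nothing available on these compounds accounts for this order.

Open, from the compounds shown here alone, is where pyrrolidin-1-yl or diethylamino would fall relative to compound 4 and compound 2. Also open, going by these compounds, is whether 4-methylpiperazin-1-yl, which replaces the ring nitrogen's hydrogen with methyl, would stay near compound 3.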